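This account rests on a few compounds, and the source may have more. Where it says the series, first, only, none or still open, it means among the compounds named here.

Measured so far:
compound 1 `COc1ccccc1/C=N/NC(=O)c1ccc(-c2ccc(F)cc2F)o1` — 59.5%
compound 2 `O=C(N/N=C/c1ccc(O)cc1)c1ccc(-c2ccc(F)cc2)o1` — 11%
compound 3 `Cc1cccc(/C=N/NC(=O)c2ccc(-c3ccccc3[N+](=O)[O-])o2)c1` — 10.3%

In a functional assay on KB cells (Homo sapiens) for inhibition, read by sulforhodamine B assay, with a stated time of 48 h, tested at 10 uM (on this read-out higher numbers stand for more inhibition of growth at the one concentration tested and lower numbers for less inhibition of growth), compound 2 and compound 3 lie within the scatter of each other, while compound 1 sits beyond the scatter above both. Compound 4 `O=C(N/N=C/c1ccccc1O)c1ccc(-c2ccc(F)cc2)o1` keeps every atom of compound 2 and joins them differently: 2-hydroxyphenyl in place of 4-hydroxyphenyl on a carbon with a double bond to nitrogen. Among the measured compounds shown here, no measured pair shows this kind of rearrangement, and compound 1 differs from compound 2 in more than one place, so it gives no direct guide. A modest rise beyond the scatter is expected for compound 4, with wide uncertainty, giving the step of a number 14 percentage points higher from compound 2 to compound 4 (beyond the scatter) in this assay. The estimate for compound 4 in this assay is therefore 25%, within 5% to 55%.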

Compound 4, percent growth inhibition at one concentration: 53.9%
Compound 4: middle estimate off by 28.9 percentage points, on the low side, and the stated range covers the measured number.
By their numbers in this assay, from the lowest: compounds 3 and 2 (each within the scatter of the next); then compounds 4 and 1 (each within the scatter of the next).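

Replacing 4-hydroxyphenyl with 2-hydroxyphenyl on a carbon with a double bond to nitrogen gives a number 42.9 percentage points higher from compound 2 to compound 4 (beyond the scatter) in this assay. The two groups have identical atom, donor and acceptor counts, so these counts cannot separate the compounds, and the arrangement of the group alone accompanies this large change. Nothing measured here gives a reason for the step. The compounds shown leave open whether 3-hydroxyphenyl or 2-aminophenyl at this place would perform like 2-hydroxyphenyl, and whether the same swap would give a similar step with other groups elsewhere on the shared core.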